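Ester chain swap on the shared core

A few compounds are considered here, and "the series" means these few. Any claim that something is new, unique, unknown or untested is made for them only; others in the source may bear on it.

In an ADME assay on HepG2 2.2.15 cells (Homo sapiens) for cytotoxicity (on this read-out lower numbers stand for higher toxicity in this test and higher numbers for lower toxicity in this test), compound 1 (`O=CCc1c(-c2ccccc2Cl)c2cc(Cl)ccc2[nH]c1=O`) gives 120000 nM and compound 2 (`O=C(O)CCCC(=O)OCCc1c(-c2ccccc2Cl)c2cc(Cl)ccc2[nH]c1=O`) gives 110000 nM, two values within the scatter of each other. Compound 3 (`COCC(=O)OCCc1c(-c2ccccc2Cl)c2cc(Cl)ccc2[nH]c1=O`) has methoxy in place of 2-carboxyethyl on a saturated chain carbon bound to a carbonyl carbon. Among the compounds with values here, one measured step bears on this change, a 1.1-fold lower number from compound 1 to compound 2 (0.04 log units; within the scatter), and it lies within the scatter. No shift beyond the scatter is therefore expected in this assay, and the expected step is a 1.2-fold lower number from compound 2 to compound 3 (0.06 log units; within the scatter). Compound 3 is estimated at 95000 nM, with an expected range of 45000 nM to 190000 nM.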

Compound 3, half-maximal cytotoxic concentration: 74000 nM
Estimate against measurement, compound 3: 1.3-fold (0.11 log units) above; low and high end bracket the measured number.
By their numbers in this assay, from the lowest: compounds 3, 2 and 1 (each within the scatter of the next).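

In this assay, methoxy in place of 2-carboxyethyl on a saturated chain carbon bound to a carbonyl carbon gives a step within the scatter (a 1.5-fold lower number from compound 2 to compound 3 (0.17 log units; within the scatter)), even with the hydrogen-bond donor of 2-carboxyethyl gone. The full replacement of formyl by (((methoxymethyl)carbonyl)oxy)methyl also stays within the scatter (a 1.6-fold lower number from compound 1 to compound 3 (0.21 log units; within the scatter)), so the three compounds cannot be told apart on this read-out. No supporting data bear on why these steps are small.

As far as these compounds go, whether an amine in place of methoxy at this carbon would give a step beyond the scatter remains open. The same holds for a longer alkyl chain there.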